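The source may hold more compounds than are shown below. What is called first, only, known or untested is meant among the compounds shown, and "the series" means these compounds.

Measured so far in an ADME assay on BJ cells (Homo sapiens) for cytotoxicity, read by CellTiter-Glo and resazurin assay, with a stated time of 72 h; on this read-out higher numbers stand for an effect only at larger amounts of compound and lower numbers for an effect already at smaller amounts:
- compound 1 `CCOc1cccc(-c2ccc(C(=O)N(Cc3cccc(OCCCCCC(=O)O)c3)C(C)C)cc2)c1` gives > 20800 nM (a limit of the assay)
- compound 2 `CC(C)N(Cc1cccc(OCCCCCC(=O)O)c1)C(=O)c1ccc(-c2cccc(O)c2)cc1` gives > 26000 nM (a limit of the assay)

Compound 2 therefore stands at a limit, > 26000 nM, and has no numerical value. Compound 3 `CC(C)N(Cc1cccc(OCCCCCC(=O)O)c1)C(=O)c1ccc(-c2cccc(Br)c2)cc1` carries bromo in place of hydroxy on an aromatic carbon, meta to a large group: bromo in place of hydroxy on an aromatic carbon. Within the data shown here, the only measured step that bears on this change is a step that the two limits leave unreadable from compound 1 to compound 2, so it provides no size to carry over. It involves the same oxygen-bearing position only in so far as hydroxy is present in compound 2. Compound 1 also ended at a limit, so no step beyond the usual scatter is expected in this assay and no direction can be assigned. The expected step is an at least 1.0-fold lower number from compound 2 to compound 3 (0.01 log units; that floor lies within the scatter). For compound 3 the estimated value is 25000 nM, with an expected range of 10000 nM to 45000 nM.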

Compound 3, half-maximal effective concentration: > 26000 nM
Compound 3 was reported as a limit; the forecaster's own chance of this, stated with the estimate: 80%; at least 1.0-fold (0.01 log units) between middle value and limit.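

In this assay compound 3 gives > 26000 nM, a limit of the assay. Among these compounds, compound 1 and compound 2 also stand at limits, so no step among the three can be read. The compounds shown leave open whether hydroxy, ethoxy or bromo on the aromatic ring makes any difference in this assay.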